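A few compounds are considered here, and "the series" means these few. Any claim that something is new, unique, unknown or untested is made for them only; others in the source may bear on it.

Compound 1 `COc1ccc2c(c1)OCC(=O)N2Cc1cn(Cc2ccccc2)nn1` gives 9200 nM. Compound 2 `Cc1cc2c(cc1Cl)N(Cc1cn(Cc3ccccc3)nn1)C(=O)CO2` gives only a limit, > 100000 nM. Compound 3 `O=C1COc2ccc(Cl)cc2N1Cc1cn(Cc2ccccc2)nn1` gives 55500 nM.

In a functional assay on Hep 3B2 cells (Homo sapiens) for cytotoxicity, read by MTT assay, with a stated time of 6 days (a lower number here means a stronger inhibitor, a higher number a weaker inhibitor), compound 3 gives 55500 nM, the highest of the two numbers shown; compound 1 lies lower by a gap beyond the scatter. The value of compound 2 is a limit of the assay. For the measured compounds named here, the one measured step, an at least 1.8-fold lower number from compound 2 to compound 3 (0.25 log units; that floor lies within the scatter), concerns hydrogen in place of methyl on an aromatic carbon and rests on that limit (the limit of > 100000 nM in this assay, at which 1 of the 3 values shown sits), so it says nothing about the change to compound 4 `CCOC(=O)c1ccc2c(c1)N(Cc1cn(Cc3ccccc3)nn1)C(=O)CO2`: ethoxycarbonyl in place of chloro on an aromatic carbon. Going by the values given here, no measured step bears on it, so no step beyond the scatter is expected, a 1.2-fold lower number from compound 3 to compound 4 (0.09 log units; within the scatter). Compound 4 is estimated at 45000 nM, between 9000 nM and 150000 nM.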

Compound 4, half-maximal inhibitory concentration: 17100 nM
Estimate against measurement, compound 4: 2.6-fold (0.42 log units) above; the range from low to high includes it.
By their numbers in this assay, from the lowest: compounds 1 and 4 (each within the scatter of the next); then compound 3. At a limit, above all of these: compound 2.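

In this assay, ethoxycarbonyl in place of chloro on this aromatic carbon gives a 3.2-fold lower number from compound 3 to compound 4 (0.51 log units; beyond the scatter), the only readable step among these compounds that lies beyond the scatter. It shows that the number at this position responds to the group it carries, and that the larger ethoxycarbonyl does not raise it. Nothing measured here accounts for this step. The compounds shown leave open whether a carboxylic acid or an amine on this carbon would lower the number further, and whether a longer ester chain would do the same.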